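A few compounds are considered here, and "the series" means these few. Any claim that something is new, unique, unknown or untested is made for them only; others in the source may bear on it.

Of the compounds shown here, three of the shared core have been measured in an ADME assay on Vero cells (Chlorocebus sabaeus) for cytotoxicity, read by fluorescence and resazurin assay, with a stated time of 3 days; on this read-out higher numbers stand for lower toxicity in this test and lower numbers for higher toxicity in this test. Compound 1 `CC(=O)C[C@H]1O[C@@H](On2cc(CN3C(=O)/C(=N\Nc4cccc(Cl)c4)c4ccccc43)nn2)[C@H](OC(C)=O)[C@@H](OC(C)=O)[C@@H]1OC(C)=O` gives 117000 nM, compound 2 `CC(=O)C[C@H]1O[C@@H](On2cc(CN3C(=O)/C(=N\Nc4ccc(C#N)cc4)c4ccccc43)nn2)[C@H](OC(C)=O)[C@@H](OC(C)=O)[C@H]1OC(C)=O` gives 75500 nM, and compound 3 `CC(=O)C[C@H]1O[C@@H](On2cc(CN3C(=O)/C(=N\Nc4ccc(F)cc4)c4ccccc43)nn2)[C@H](OC(C)=O)[C@@H](OC(C)=O)[C@H]1OC(C)=O` gives 78600 nM. Compound 3 stands second highest of the three numbers; its nearest neighbour is compound 2, and the furthest is compound 1, both within the usual scatter of it. Among the compounds with values here, the one step measured between compounds differing in a single place, a 1.0-fold higher number from compound 2 to compound 3 (0.02 log units; within the scatter), shows no movement beyond the scatter.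

Compound 4 `CC(=O)C[C@H]1O[C@@H](On2cc(CN3C(=O)/C(=N\Nc4cccc(Cl)c4)c4ccccc43)nn2)[C@H](OC(C)=O)[C@@H](OC(C)=O)[C@H]1OC(C)=O` is the next compound to be measured in this assay. It differs from compound 3 as follows: 3-chlorophenyl in place of 4-fluorophenyl on an amine nitrogen. Within the data shown here, compound 1 carries the same 3-chlorophenyl group on a differently configured sugar, and its number sits a little higher than those of compounds 2 and 3, though no single-place step connects it to compound 4. With only that to lean on, the step for compound 4 is expected to be a 1.3-fold higher number from compound 3 to compound 4 (0.10 log units; within the scatter), a change that may not exceed the scatter. Compound 4 is therefore estimated at 100000 nM, between 50000 nM and 200000 nM.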

Compound 4, half-maximal cytotoxic concentration: 87900 nM
The estimate for compound 4 lay 1.1-fold (0.06 log units) above the measured number, and the stated range covers the measured number.
By their numbers in this assay, from the lowest: compounds 2, 3, 4 and 1 (each within the scatter of the next).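

In this assay the group on the amine nitrogen now spans three aryl groups on one sugar configuration, and neither a 1.1-fold higher number from compound 3 to compound 4 (0.05 log units; within the scatter) nor a 1.2-fold higher number from compound 2 to compound 4 (0.07 log units; within the scatter) leaves the scatter, so 3-chlorophenyl, 4-fluorophenyl and 4-cyanophenyl cannot be told apart at this position. Compound 1 is now joined to the series by a single difference, and a 1.3-fold lower number from compound 1 to compound 4 (0.12 log units; within the scatter) also stays within the scatter. This gives a direct reading of one stereocentre on the sugar with the aryl group held constant, which rests on this: the fact that compounds 1 and 4 differ only in the configuration as drawn.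

Still open, on these data alone, is whether a carboxylic acid or an amine on that phenyl ring, or a plain alkyl chain in its place, would move the number beyond the scatter. Also open, as far as these compounds go, is what free hydroxyl groups on the sugar would do in place of the acetate esters.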